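This account rests on a few compounds, and the source may have more. Where it says the series, first, only, none or still open, it means among the compounds named here.

Compound 3 `O=C(CN(c1nc(Cl)nc2c1ncn2C1CCCCO1)C1CC1)N[C@@H](CC(=O)OCc1ccccc1)C(=O)OCc1ccccc1` belongs to a set of three compounds sharing one core. In a functional assay on the whole organism with Mus musculus as the target, with a stated time of 90 min, at a dose of 25 umol/kg by the oral route (on this read-out lower numbers stand for a weaker effect and higher numbers for a stronger effect at the one dose given), compound 1 `O=C(O)CN(c1nc(Cl)nc2c1ncn2C1CCCCO1)C1CC1` gives 8.22%, compound 2 `C[C@H](NC(=O)CN(c1nc(Cl)nc2c1ncn2C1CCCCO1)C1CC1)C(=O)OCc1ccccc1` gives 32.1%, and compound 3 gives 25.1%. Compound 3 thus stands second of the three numbers, its nearest neighbour being compound 2, while its gap to compound 1 lies beyond the scatter. For the measured compounds named here, the one step touching this pair is a number 7 percentage points lower from compound 2 to compound 3 (within the scatter). Compound 4 `CC[C@H](C)[C@H](NC(=O)CN(c1nc(Cl)nc2c1ncn2C1CCCCO1)C1CC1)C(=O)OCc1ccccc1` differs from compound 3 by sec-butyl in place of (benzyloxycarbonyl)methyl on a saturated chain carbon bound to an amide-type nitrogen and a carbonyl carbon. Going by the values given here, because the only related step, a number 7 percentage points lower from compound 2 to compound 3 (within the scatter), stayed within the scatter, a comparably small step is expected here, a number 4.9 percentage points higher from compound 3 to compound 4 (within the scatter), leaning toward the number of compound 2. Compound 4 is therefore estimated at 30%, within a range from 15% to 45%.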

Compound 4, a percentage reported as activity, at one dose (the size of the read-out at that dose, not a potency): 22.6%
The estimate for compound 4 lay 7.4 percentage points above the measured number; the range from low to high includes it.
By their numbers in this assay, from the lowest: compound 1; then compounds 4, 3 and 2 (each within the scatter of the next).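

On the saturated chain carbon bound to an amide-type nitrogen and a carbonyl carbon, sec-butyl in place of (benzyloxycarbonyl)methyl gives a number 2.5 percentage points lower from compound 3 to compound 4 (within the scatter), and sec-butyl in place of methyl gives a number 9.5 percentage points lower from compound 2 to compound 4 (within the scatter). In this assay, then, these three side groups cannot be told apart at this carbon, even though only one of them carries an aromatic ring. No independent measurement is available that could explain this result. Still open, from the compounds shown here alone, is how a side group ending in an amine or a hydroxyl group would behave at this carbon.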